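Replacing Nitro by Amino in Two Inactive Sulfone Series

A few compounds are considered here, and "the series" means these few. Any claim that something is new, unique, unknown or untested is made for them only; others in the source may bear on it.

Measured so far in a functional assay on T47D cells (Homo sapiens) for cytotoxicity, read by MTT assay, with a stated time of 72 h; a higher number here means a weaker inhibitor of growth, a lower number a stronger inhibitor of growth:
Compound 1 `COc1ccc(CS(=O)(=O)/C=C/c2c(OC)cccc2OC)cc1[N+](=O)[O-]` gives > 30000 nM.
Compound 2 `COc1ccc(CS(=O)(=O)CC(=O)Nc2ccccc2)cc1[N+](=O)[O-]` gives > 30000 nM.
Compound 3 `COc1ccc(CS(=O)(=O)CC(=O)Nc2ccccc2)cc1N` gives > 30000 nM.

Each of these three values is a limit of this assay and not a number. The core of compound 1 and the core of compound 2 differ, but that difference is not broken down here.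

Compound 2 and compound 3 differ by one change, (amino in place of nitro on an aromatic carbon). The step that the two limits leave unreadable from compound 2 to compound 3 cannot be read, since both ends sit at the limit of > 30000 nM in this assay, at which 3 of the 3 values shown sit.

Compound 4 `COc1ccc(CS(=O)(=O)/C=C/c2c(OC)cccc2OC)cc1N` has not yet been measured. It differs from compound 1 by amino in place of nitro on an aromatic carbon, the same change as between compound 2 and compound 3, at a place described in the same words.

Because compound 2 and compound 3 both sit at the limit of > 30000 nM in this assay, at which 3 of the 3 values shown sit, the change gives no sign of bringing growth inhibition into the measurable range. The step expected is a step that the limit leaves unreadable from compound 1 to compound 4. Compound 4 is therefore estimated at 45000 nM in this assay, most likely again reported only as a limit.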

Compound 4, concentration for 50% growth inhibition: 50 nM
The estimate for compound 4 lay 900-fold (2.95 log units) above the measured number; the whole stated range lies above it.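

In this assay, amino in place of nitro gives an at least 600-fold lower number from compound 1 to compound 4 (2.77 log units; beyond the scatter), so on this core a single change separates a compound reported only as a limit from one with a measured value. On the core of compound 2 the same change cannot be read, so that pair gave no real sign of what the change would do on another core: the limit of > 30000 nM in this assay, at which 3 of the 4 values shown sit. The result does not show that the two cores truly respond differently, as the step on the core of compound 2 has no size to compare with, and two cores cannot support a rule for a third.

The compounds shown leave open whether amino itself is needed on the core of compound 4, or whether a hydroxyl group or an acetylated amino group in its place would give a similar value. Also open, from the compounds shown here alone, is whether the methoxy group on the same ring plays a part, as an ethoxy group there would test.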